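Swapping cyano for chloro on compound 3

A few compounds are considered here, and "the series" means these few. Any claim that something is new, unique, unknown or untested is made for them only; others in the source may bear on it.

- compound 1 `Cn1c(-c2ccc(Cl)cc2)cnc1NC(=O)c1ncc[nH]1`: 52000 nM
- compound 2 `COc1cccc(-c2cnc(NC(=O)c3ncc[nH]3)n2C)c1`: > 100000 nM (a limit)
- compound 3 `Cn1c(-c2cccc(C#N)c2)cnc1NC(=O)c1ncc[nH]1`: > 50000 nM (a limit)

The values come from a toxicity assay on THP-1 cells (Homo sapiens) for inhibition; a higher number here means that more compound is tolerated, a lower number that less compound is tolerated. Compound 3 gives only a limit, > 50000 nM, and not a number. Compound 4 `Cn1c(-c2cccc(Cl)c2)cnc1NC(=O)c1ncc[nH]1` has chloro in place of cyano on an aromatic carbon. Going by the values given here, the one measured step involving cyano, a step that the two limits leave unreadable from compound 2 to compound 3, replaces methoxy and offers no size or direction to carry over. The expectation therefore rests on compound 1, which also carries chloro and gives 52000 nM. No change beyond the scatter is expected, and the estimated change is a step that the limit leaves unreadable from compound 3 to compound 4. For compound 4 the expected value is 55000 nM, with an estimated range from 25000 nM to 100000 nM.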

Compound 4, half-maximal cytotoxic concentration: 55000 nM
The estimate for compound 4 equals the measured number at the digits printed; low and high end bracket the measured number.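

In this assay, 3-chlorophenyl in place of 4-chlorophenyl gives a 1.1-fold higher number from compound 1 to compound 4 (0.02 log units; within the scatter), so moving the chloro makes no readable difference between these two compounds. Chloro in place of methoxy gives an at least 1.8-fold lower number from compound 2 to compound 4 (0.25 log units; that floor lies within the scatter), so this step is not shown to go beyond the scatter either. The step from compound 3 to compound 4 cannot be read, as compound 3 gives only a limit: the limit of > 50000 nM in this assay, at which 1 of the 4 values shown sits.

Going by these compounds, whether an amine or a carboxylic acid at this place on the aromatic ring would shift the number beyond the scatter remains open.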